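This account rests on a few compounds, and the source may have more. Where it says the series, first, only, none or still open, it means among the compounds named here.

Working notes on the series. Compound 1 `O=C(/C=C/c1cccc2ccccc12)c1cccc(NC(=O)c2cc(-c3ccncc3)n[nH]2)c1` gives 64500 nM in a functional assay, read by spectrophotometry, tested at 100 uM; on this read-out lower numbers stand for stronger inhibition and higher numbers for weaker inhibition. Compound 2 `O=C(/C=C/c1ccc(F)cc1)c1cccc(NC(=O)c2cc(-c3ccncc3)n[nH]2)c1` gives 56000 nM in this assay; the step of a 1.2-fold lower number from compound 1 to compound 2 (0.06 log units; within the scatter) is within the scatter, so the two numbers shown are not separable, and compound 1 stands on neither side of compound 2 with any certainty. Compound 3 `CN(C)c1ccc(/C=C/C(=O)c2cccc(NC(=O)c3cc(-c4ccncc4)n[nH]3)c2)cc1` differs from compound 1 by 4-(dimethylamino)phenyl in place of naphthalen-1-yl on a double-bonded chain carbon bound to a double-bonded chain carbon. Among the measured compounds shown here, the only measured step at this place of the shared core is a 1.2-fold lower number from compound 1 to compound 2 (0.06 log units; within the scatter), where a single six-membered aromatic ring in place of naphthalen-1-yl left the number unchanged beyond the scatter. For the measured compounds named here, the change to 4-(dimethylamino)phenyl has no measured precedent of its own, so the expectation for compound 3 rests on that one step: a step of a 1.2-fold lower number from compound 1 to compound 3 (0.07 log units; within the scatter) of no clear direction is expected. For compound 3 the estimate is 55000 nM, with a range from 25000 nM to 130000 nM.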

Compound 3, half-maximal inhibitory concentration: 41900 nM
Beside the measured number, compound 3's estimate is 1.3-fold (0.12 log units) above it, and the stated range covers the measured number.
By their numbers in this assay, from the lowest: compounds 3, 2 and 1 (each within the scatter of the next).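

In this assay, 4-(dimethylamino)phenyl in place of naphthalen-1-yl on a double-bonded chain carbon gives no separable change (step: a 1.5-fold lower number from compound 1 to compound 3 (0.19 log units; within the scatter)), and dimethylamino in place of fluoro on an aromatic carbon gives none either (step: a 1.3-fold lower number from compound 2 to compound 3 (0.13 log units; within the scatter)). This place of the shared core has now carried naphthalen-1-yl, 4-fluorophenyl and 4-(dimethylamino)phenyl with no step beyond the scatter, including a change that brings in a nitrogen and a hydrogen-bond acceptor. No measurement at hand gives a reason for these numbers.

The compounds shown leave open whether a carboxylic acid on this ring, or cyclohexyl in place of it, would move the number beyond the scatter. They also leave open whether a change elsewhere on the shared core would do so.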